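A Basic Side Chain on the Shared Core

A few compounds are considered here, and "the series" means these few. Any claim that something is new, unique, unknown or untested is made for them only; others in the source may bear on it.

compound 1 `Cn1c(=N)sc2cc(OC(F)(F)F)ccc21`: 5 mg/kg
compound 2 `CSCn1c(=N)sc2cc(OC(F)(F)F)ccc21`: 3 mg/kg

Going by the values given here, in a functional assay on the whole organism with Rattus norvegicus as the target (on this read-out lower numbers stand for an effect already at smaller amounts and higher numbers for an effect only at larger amounts of compound), compound 2 gives 3 mg/kg, the lowest of the two numbers, while compound 1 gives 5 mg/kg; the only step seen so far, a 1.7-fold lower number from compound 1 to compound 2 (0.22 log units; within the scatter), concerns the same saturated chain carbon. Compound 3 `CN(C)CCn1c(=N)sc2cc(OC(F)(F)F)ccc21` carries the next change there: (dimethylamino)methyl in place of methylsulfanyl on a saturated chain carbon bound to an aromatic nitrogen. Among the compounds with values here, no measured step exchanges methylsulfanyl for (dimethylamino)methyl, and the one change made at this position stayed within the scatter. Compound 3 is therefore expected to stay close to compound 2, with no change at the digits printed from compound 2 to compound 3 (within the scatter). The estimate for compound 3 in this assay is 3 mg/kg, in the range 1 mg/kg to 9 mg/kg.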

Compound 3, dose for half-maximal effect: 2.3 mg/kg
For compound 3 the middle estimate is 1.3-fold (0.12 log units) above the measured one, within the range that was stated.
By their numbers in this assay, from the lowest: compounds 3, 2 and 1 (each within the scatter of the next, the first and the last beyond it).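

In this assay the exchange of methylsulfanyl for (dimethylamino)methyl gives a 1.3-fold lower number from compound 2 to compound 3 (0.12 log units; within the scatter) and so separates neither side chain from the other on this read-out. Going by these compounds alone, measured against hydrogen at the same saturated chain carbon, (dimethylamino)methyl gives a 2.2-fold lower number from compound 1 to compound 3 (0.34 log units; beyond the scatter) and is the first change here to pass the scatter, though only modestly. Nothing available bears on the reason for this result. The compounds shown leave open how a carboxylic acid or a longer chain ending in a piperidine would read at this carbon.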